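Methylsulfonyl for oxan-4-yl on the benzimidazole of compound 1

A few compounds are considered here, and "the series" means these few. Any claim that something is new, unique, unknown or untested is made for them only; others in the source may bear on it.

Measured so far:
compound 1 `Cc1nc(C)n(CC(=O)N2CCN(c3sc(C(F)(F)F)nc3-c3nc4ccc(C5CCOCC5)cc4[nH]3)C[C@H]2C)n1` — 3.3 nM
compound 2 `C[C@@H]1CN(c2sc(C(F)(F)F)nc2-c2nc3cc(OCCO)ccc3[nH]2)CCN1C(=O)Cn1cnc2cccnc21` — 2.1 nM

In a functional assay on CHO-K1 cells for antagonist activity at C-X-C chemokine receptor type 3 (Homo sapiens), read by FLIPR, with a stated time of 10 min, in the presence of a further agent that is not named here (on this read-out higher numbers stand for weaker inhibition and lower numbers for stronger inhibition), compound 1 gives 3.3 nM; compound 2 gives 2.1 nM, and the gap between the two is within the usual scatter, so neither can be called apart from the other. Compound 3 `Cc1nc(C)n(CC(=O)N2CCN(c3sc(C(F)(F)F)nc3-c3nc4ccc(S(C)(=O)=O)cc4[nH]3)C[C@H]2C)n1` has not yet been measured. It differs from compound 1 as follows: methylsulfonyl in place of oxan-4-yl on an aromatic carbon. Among the compounds with values here, no step between measured compounds speaks to this change, so the expectation rests on the shared core alone. The step from compound 1 to compound 3 in this assay is expected to be small, a 1.5-fold higher number from compound 1 to compound 3 (0.18 log units; within the scatter), likely not beyond the scatter. Compound 3 is estimated at 5 nM, with a range from 1.5 nM to 16 nM.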

Compound 3, half-maximal inhibitory concentration: 10 nM
Estimate against measurement, compound 3: 2.0-fold (0.30 log units) below; measured number inside the range.
By their numbers in this assay, from the lowest: compounds 2 and 1 (each within the scatter of the next); then compound 3.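

In this assay this aromatic carbon is not indifferent to its substituent: methylsulfonyl in place of oxan-4-yl gives a 3.0-fold higher number from compound 1 to compound 3 (0.48 log units; beyond the scatter) in a modest step. Within the data shown here, compound 2 differs from compound 1 in more than one place, so this is the only reading of a single change at this position. No measured evidence available here accounts for the step.

Open, on these data alone, is whether the step follows from losing the ring or from gaining the sulfonyl group. A methoxy group or a piperidine ring on the same carbon would separate the two.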